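This account rests on a few compounds, and the source may have more. Where it says the series, first, only, none or still open, it means among the compounds named here.

Measured so far:
Compound 1, `CC(O)CNC(=O)c1nc(Br)c(C(F)(F)F)cc1N`: 70 nM
Compound 2, `CC(O)(CNC(=O)c1ncc(C(F)(F)F)cc1N)C(F)(F)F`: 229 nM

In an assay on CHO cells for positive allosteric modulation of Cystic fibrosis transmembrane conductance regulator variant F508del (Homo sapiens), using a membrane potential dye, with a stated time of 30 min, in the presence of a further agent that is not named here (on this read-out lower numbers stand for an effect already at smaller amounts and higher numbers for an effect only at larger amounts of compound), compound 1 gives 70 nM and compound 2 gives 229 nM. Compound 2 thus stands at the higher of the two numbers, and its gap to compound 1 lies beyond the scatter of repeated measurements, so compound 2 is the weaker of the two in this assay.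

Compound 3, `Cc1nc(C(=O)NCC(C)(O)C(F)(F)F)c(N)cc1C(F)(F)F`, is not yet measured. It differs from compound 2 by methyl in place of hydrogen on an aromatic carbon, placed next to the ring nitrogen, ortho to a trifluoromethyl group and para to an amino group. Among the compounds with values here, no measured pair shows what such a methyl does on this core, so nothing here fixes the size or direction of the step. One added methyl is a small change, and the expectation is a step of a 1.1-fold lower number from compound 2 to compound 3 (0.06 log units; within the scatter), not beyond the scatter. Compound 3 is therefore estimated at 200 nM, with a likely range from 70 nM to 600 nM.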

Compound 3, half-maximal effective concentration: 240 nM
Compound 3: middle estimate off by 1.2-fold (0.08 log units), on the low side; the range from low to high includes it.
By their numbers in this assay, from the lowest: compound 1; then compounds 2 and 3 (each within the scatter of the next).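

Within the data shown here, this is the first step in which only one place changes. In this assay methyl in place of hydrogen on the aromatic carbon next to the ring nitrogen gives a 1.0-fold higher number from compound 2 to compound 3 (0.02 log units; within the scatter) on the shared core, so the two compounds cannot be told apart. This carbon, ortho to a trifluoromethyl group and para to an amino group, can therefore carry a methyl with no difference that repeated measurements could separate, at least with this side chain. There is no independent measurement that would explain this result.

On these data alone, one small group says little about larger or different ones, so it remains open whether a longer chain such as ethyl, an amine or a carboxylic acid on this carbon would also leave the number unchanged. As far as these compounds go, it is also open whether a methyl here would behave the same way alongside a different amide side chain.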